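Replacing naphthalen-1-yl in compound 1: working notes

This account rests on a few compounds, and the source may have more. Where it says the series, first, only, none or still open, it means among the compounds named here.

For the measured compounds named here, in a functional assay on HCT-116 cells (Homo sapiens) for cytotoxicity, read by sulforhodamine B assay, with a stated time of 48 h (a lower number here means a stronger inhibitor, a higher number a weaker inhibitor), compound 1 (`COc1cc(/C=C/C(=O)/C=C/c2cccc3ccccc23)ccc1OCc1cn(CCCOc2cc(=O)oc3ccccc23)nn1`) gives 10400 nM and compound 2 (`COc1cccc(/C=C/C(=O)/C=C/c2ccc(OCc3cn(CCOc4cc(=O)oc5ccccc45)nn3)c(OC)c2)c1`) gives 9760 nM and the two numbers sit within the scatter of each other, so compound 1 stands level with the only other measured compound. Compound 3 (`COc1ccc(/C=C/C(=O)/C=C/c2ccc(OCc3cn(CCCOc4cc(=O)oc5ccccc45)nn3)c(OC)c2)cc1OC`) is still unmeasured and differs from compound 1 as follows: 3,4-dimethoxyphenyl in place of naphthalen-1-yl on a double-bonded chain carbon bound to a double-bonded chain carbon. Going by the values given here, no measured pair shows this change alone. The estimated step of a 1.3-fold lower number from compound 1 to compound 3 (0.11 log units; within the scatter) is expected to stay within the scatter, with no direction called. In this assay compound 3 is estimated at 8000 nM (expected range 3500 nM to 18000 nM).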

Compound 3, half-maximal inhibitory concentration: 11000 nM
Beside the measured number, compound 3's estimate is 1.4-fold (0.14 log units) below it; the range from low to high includes it.
By their numbers in this assay, from the lowest: compounds 2, 1 and 3 (each within the scatter of the next).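

In this assay, this change on a double-bonded chain carbon bound to a double-bonded chain carbon now has a direct reading, a 1.1-fold higher number from compound 1 to compound 3 (0.02 log units; within the scatter), so 3,4-dimethoxyphenyl and naphthalen-1-yl stand level at this position. The two groups read alike even though 3,4-dimethoxyphenyl brings one six-membered aromatic ring and two hydrogen-bond acceptors, while naphthalen-1-yl brings two such rings and none. No measurement here bears on why this is so.

Open, from the compounds shown here alone, is whether a group carrying an amine or a carboxylic acid at this position would give a step beyond the scatter. The compounds shown do not yet mark out what this position will accept.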